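Oxadiazole in place of fluoroisopropyl on the piperidine amide

The source may hold more compounds than are shown below. What is called first, only, known or untested is meant among the compounds shown, and "the series" means these compounds.

Of the compounds shown here, three sharing one core have been measured in a functional assay on isolated protein for inhibition of Glucose-dependent insulinotropic receptor (Rattus norvegicus), read by HTRF and cAMP accumulation; a lower number here means that less compound is needed, a higher number that more compound is needed for the effect. Compound 1 `Cc1nc(S(C)(=O)=O)ccc1Oc1ncnc(OC2CCN(C(=O)OC(C)(C)C#N)CC2)c1F` gives 1320 nM, compound 2 `Cc1nc(S(C)(=O)=O)ccc1Oc1ncnc(OC2CCN(C(=O)O[C@H](C)C(F)(F)F)CC2)c1F` gives 110 nM, and compound 3 `Cc1nc(S(C)(=O)=O)ccc1Oc1ncnc(OC2CCN(C(=O)C(C)(C)F)CC2)c1F` gives 296 nM. Compound 3 thus holds the second highest of the three numbers: it sits a 2.7-fold higher number from compound 2 to compound 3 (0.43 log units; beyond the scatter) and a 4.5-fold lower number from compound 1 to compound 3 (0.65 log units; beyond the scatter).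

Compound 4 `Cc1nc(S(C)(=O)=O)ccc1Oc1ncnc(OC2CCN(C(=O)c3noc(C(C)(C)F)n3)CC2)c1F` differs from compound 3 at the carbonyl carbon: a group of 9 heavy atoms (5 carbon, 2 nitrogen, 1 oxygen, 1 fluorine; one five-membered aromatic ring with 3 hetero atoms) in place of a group of 4 heavy atoms (3 carbon, 1 fluorine; no ring), on a carbonyl carbon. The steps measured so far all change what sits on that carbonyl carbon, so they bear on this one. Within the data shown here, they were large or modest in size, a 12-fold lower number from compound 1 to compound 2 (1.08 log units; beyond the scatter), a 4.5-fold lower number from compound 1 to compound 3 (0.65 log units; beyond the scatter) and a 2.7-fold higher number from compound 2 to compound 3 (0.43 log units; beyond the scatter), yet none of them brought in a ring, and no measured pair shows what a five-membered aromatic ring with 3 hetero atoms in this place does. The 1-fluoro-1-methylethyl group itself is kept, now carried on the ring. On this basis the step from compound 3 to compound 4 is expected to be small, a 1.2-fold lower number from compound 3 to compound 4 (0.07 log units; within the scatter), with the direction uncertain. For compound 4 the estimate in this assay is 250 nM, within a range from 70 nM to 900 nM.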

Compound 4, half-maximal effective concentration: 103 nM
Compound 4: middle estimate off by 2.4-fold (0.39 log units), on the high side; the range from low to high includes it.
By their numbers in this assay, from the lowest: compounds 4 and 2 (each within the scatter of the next); then compound 3; then compound 1.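

In this assay, carrying the 1-fluoro-1-methylethyl group on a five-membered aromatic ring with 3 hetero atoms, rather than directly on the carbonyl carbon, gives a 2.9-fold lower number from compound 3 to compound 4 (0.46 log units; beyond the scatter), so this first ring at the position takes the number beyond the scatter instead of merely being tolerated. The ring-bearing group and the 1-(trifluoromethyl)ethoxy group cannot be told apart in this assay, with a 1.1-fold lower number from compound 2 to compound 4 (0.03 log units; within the scatter), whereas the 1-cyano-1-methylethoxy group stays well separated from the ring-bearing group, with a 13-fold lower number from compound 1 to compound 4 (1.11 log units; beyond the scatter), so a group without the oxygen on the carbonyl carbon can match the best number seen here within the scatter. Nothing available explains the lower number of compound 4.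

The compounds shown leave open whether the ring or the 1-fluoro-1-methylethyl group on it accounts for the step, a question that the same ring carrying a methyl group, a tert-butyl group or a hydrogen atom in that place would address. On these data alone, it also remains open whether a phenyl ring or a pyridine ring on the carbonyl carbon would behave like this ring, or whether an amine or a carboxylic acid on the ring would be accepted.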